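Adding a chlorine to the anilide of compound 2

The source may report more compounds than this note shows. Statements on the series, on what has been measured and on what is new or still open speak of the compounds shown alone.

Compound 2 `Cc1noc(C)c1-c1cnc(N)c(Oc2ccc(C(=O)Nc3ccccc3)cc2)n1` is tested in a functional assay on HepG2 cells (Homo sapiens) for inhibition, read by MTT assay, with a stated time of 72 h (a higher number here means a weaker inhibitor, a lower number a stronger inhibitor), where compound 2 gives 11800 nM. Among the two compounds measured so far, compound 2 has the highest number, and its nearest neighbour is compound 1 `CCCNC(=O)c1ccc(Oc2nc(-c3c(C)noc3C)cnc2N)cc1`, for which compound 1 gives 6880 nM. Among the compounds with values here, the one known step, a 1.7-fold higher number from compound 1 to compound 2 (0.23 log units; within the scatter), exchanges the propyl group on the amide nitrogen for a phenyl ring. Compound 3 `Cc1noc(C)c1-c1cnc(N)c(Oc2ccc(C(=O)Nc3ccccc3Cl)cc2)n1` keeps the phenyl of compound 2 and changes it as follows: chloro in place of hydrogen on an aromatic carbon. Within the data shown here, no measured step touches the phenyl ring itself, so nothing in hand shows how this assay responds to a chlorine there. The expectation is therefore a number close to that of compound 2, and compound 3 is estimated at 10000 nM, with a plausible range of 3000 nM to 35000 nM, a step of a 1.2-fold lower number from compound 2 to compound 3 (0.07 log units; within the scatter) that is expected to stay within the scatter.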

Compound 3, half-maximal inhibitory concentration: > 100000 nM
Compound 3: only a limit was reported; the forecaster's own chance of this, stated with the estimate: 15%; at least 10-fold (1.00 log units) between middle value and limit.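

In this assay, compound 3 stands at a limit of the assay and not at a number: the limit of > 100000 nM in this assay, at which 1 of the 3 values shown sits.

A single chloro on an aromatic carbon, ortho to a large group, gives an at least 8.4-fold higher number from compound 2 to compound 3 (0.92 log units; beyond the scatter), so this position on the anilide ring responds far more strongly than the earlier exchange of propyl for phenyl, which gave only a 1.7-fold higher number from compound 1 to compound 2 (0.23 log units; within the scatter). Compared with the propyl amide, the 2-chlorophenyl group gives an at least 14-fold higher number from compound 1 to compound 3 (1.16 log units; beyond the scatter), so the change to the phenyl ring, not the phenyl ring alone, carries the series beyond the scatter.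

The compounds shown leave open whether a smaller fluoro or a methoxy group in the same place would weaken inhibition as much. They also leave open whether the chloro would have the same effect on another carbon of the phenyl ring.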